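Acetyl on the hydroxymethyl group of compound 2

The compounds below may be only part of what the source reports. "The series", "measured", "known", "first", "only" and "open" are said of these compounds alone.

In a functional assay on ZR-75-1 cells (Homo sapiens) for cytotoxicity, read by MTT assay, with a stated time of 72 h (on this read-out higher numbers stand for an effect only at larger amounts of compound and lower numbers for an effect already at smaller amounts), compound 1 (`CCc1cccc2c(O)c(-c3occ(C)c3C(=O)O)ccc12`) gives 0.3 ug/mL and compound 3 (`CCOc1c(-c2occ(C)c2CO)ccc2c(CC)cccc12`) gives 1.4 ug/mL. Compound 2 (`CCc1cccc2c(OC)c(-c3occ(C)c3CO)ccc12`) gives > 10 ug/mL, which is a limit of the assay and not a number. Among the values shown, compound 2 thus stands at the limit of > 10 ug/mL in this assay, at which 1 of the 3 values shown sits.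

Compound 4 (`CCc1cccc2c(OC)c(-c3occ(C)c3COC(C)=O)ccc12`) departs from compound 2 at a single place: acetyl in place of hydrogen on an oxygen on a saturated carbon. Hydroxymethyl becomes acetoxymethyl, with acetyl in place of hydrogen on an oxygen on a saturated carbon.

Going by the values given here, the one measured step that starts from compound 2 is an at least 7.1-fold lower number from compound 2 to compound 3 (0.85 log units; beyond the scatter). It comes from methyl in place of hydrogen on a saturated chain carbon bound to an oxygen on an aromatic ring, so it lies elsewhere in the structure than the new acetyl. Among the compounds with values here, no measured pair changes the hydroxymethyl group alone, and this step offers only indirect guidance. Taking an at least 7.1-fold lower number from compound 2 to compound 3 (0.85 log units; beyond the scatter) as the sole guide, a modest move toward lower numbers is expected in this assay, with a real chance that the result is again only a limit. The expected change is an at least 1.6-fold lower number from compound 2 to compound 4 (0.22 log units; that floor lies within the scatter). For compound 4 the estimated value is 6 ug/mL, with an expected range of 1.5 ug/mL to 20 ug/mL.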

Compound 4, concentration for half-maximal effect: 3.5 ug/mL
Compound 4: the middle estimate sits 1.7-fold (0.23 log units) above what was measured; the range from low to high includes it.
By their numbers in this assay, from the lowest: compound 1; then compound 3; then compound 4. At a limit, above all of these: compound 2.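

The hydroxymethyl group had not been changed on its own in any earlier pair, and acetyl on its oxygen gives the first step read at this place: in this assay, the result is an at least 2.8-fold lower number from compound 2 to compound 4 (0.45 log units; beyond the scatter). A free hydroxy on this saturated carbon is therefore not required for a measurable value in this assay, as compound 4 gives a number with that hydrogen replaced. This change at the hydroxymethyl group joins an at least 7.1-fold lower number from compound 2 to compound 3 (0.85 log units; beyond the scatter), which lies elsewhere in the structure, so changes at two separate places have now each moved the value away from the limit held by compound 2, and the printed size of the new step is only a floor: the limit of > 10 ug/mL in this assay, at which 1 of the 4 values shown sits.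

The compounds shown leave open whether the acetyl itself matters or only the loss of that hydrogen, as no other group, such as a methyl or a longer acyl chain like butanoyl, stands on this oxygen among them. They also leave open how an amine or a carboxylic acid would compare with acetoxymethyl at this place, with the rest of compound 4 kept the same.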